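The source may hold more compounds than are shown below. What is called first, only, known or untested is meant among the compounds shown, and "the series" means these compounds.

The measured compounds:
compound 1, `CC(C)(C)NCc1ccc2c(c1)CCC[C@H]2NC(=O)C[C@@H]1CCCCN1S(=O)(=O)c1ccccc1`, which in a functional assay for inhibition of B1 bradykinin receptor (Homo sapiens), read by calcium flux (a higher number here means a weaker inhibitor, a lower number a stronger inhibitor), gives 2400 nM;
compound 2, `CCCCOc1ccc(S(=O)(=O)N2CCCC[C@H]2CC(=O)N[C@@H]2CCCc3cc(CNC(C)(C)C)ccc32)cc1`, which in this assay gives 590 nM;
compound 3, `CC(C)(C)NCc1ccc2c(c1)CCC[C@H]2NC(=O)C[C@@H]1CCCCN1S(=O)(=O)c1ccc(Cl)cc1`, which in this assay gives 810 nM.

Compound 3 holds the second highest of the three numbers. Its nearest neighbour is compound 2, the gap being within the scatter (a 1.4-fold higher number from compound 2 to compound 3 (0.14 log units; within the scatter)); the furthest is compound 1, a gap beyond the scatter (a 3.0-fold lower number from compound 1 to compound 3 (0.47 log units; beyond the scatter)).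

Compound 4 is `COc1ccc(S(=O)(=O)N2CCCC[C@H]2CC(=O)N[C@@H]2CCCc3cc(CNC(C)(C)C)ccc32)cc1`. Against compound 3 the change is methoxy in place of chloro on an aromatic carbon. For the measured compounds named here, two measured steps bear on it: a 3.0-fold lower number from compound 1 to compound 3 (0.47 log units; beyond the scatter) and a 4.1-fold lower number from compound 1 to compound 2 (0.61 log units; beyond the scatter), both modest and both lowering the number when a group replaced hydrogen on that aromatic carbon. The third, a 1.4-fold higher number from compound 2 to compound 3 (0.14 log units; within the scatter), shows that chloro and butoxy gave numbers within the scatter of each other. Methoxy is a further group at the same place, and on these data it is expected to behave like the other two. For compound 4 the expected step is a 1.2-fold lower number from compound 3 to compound 4 (0.06 log units; within the scatter), within the scatter. Compound 4 is therefore estimated at 700 nM, between 300 nM and 1600 nM.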

Compound 4, half-maximal inhibitory concentration: 1400 nM
Estimate against measurement, compound 4: 2.0-fold (0.30 log units) below; low and high end bracket the measured number.
By their numbers in this assay, from the lowest: compounds 2, 3, 4 and 1 (each within the scatter of the next, the first and the last beyond it).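

Compound 4 shows that a group on this aromatic carbon, para to a large group, does not always separate a compound from the unsubstituted one: methoxy stays within the scatter of hydrogen (a 1.7-fold lower number from compound 1 to compound 4 (0.23 log units; within the scatter)), whereas butoxy and chloro each moved beyond it. Methoxy also stays within the scatter of chloro (a 1.7-fold higher number from compound 3 to compound 4 (0.24 log units; within the scatter)), so this change cannot be read as a real difference between the two groups. The alkoxy chain itself does register, however, as shortening butoxy to methoxy gives a step beyond the scatter (a 2.4-fold higher number from compound 2 to compound 4 (0.38 log units; beyond the scatter)), the first sign that the chain attached through oxygen matters here.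

On these data alone, whether an ethoxy or propoxy group would follow this trend, and what an amine or a carboxylic acid would give at the same place, remains open. The data shown offer no measurement that explains these differences.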